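Swapping 2-methoxy-5-(trifluoromethyl)phenyl for 2,4-dimethylphenyl

The compounds below may be only part of what the source reports. "The series", "measured", "known", "first", "only" and "open" are said of these compounds alone.

Measured so far in a functional assay on HepG2 cells (Homo sapiens) for antiproliferative activity, read by spectrophotometry, with a stated time of 2 days; on this read-out lower numbers stand for stronger inhibition of growth and higher numbers for weaker inhibition of growth:
- compound 1 `Cc1ccc(Nc2ncc(C(F)(F)F)c(N3Cc4cccc(N(C)S(C)(=O)=O)c4C3)n2)cc1C`: > 30000 nM (a limit)
- compound 2 `COc1ccc(C(F)(F)F)cc1Nc1ncc(C(F)(F)F)c(N2Cc3cccc(N(C)S(C)(=O)=O)c3C2)n1`: > 30000 nM (a limit)
- compound 3 `CN(c1cccc2c1CN(c1nc(Nc3cc(C(F)(F)F)cc(C(F)(F)F)c3)ncc1C(F)(F)F)C2)S(C)(=O)=O`: 10300 nM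

Compound 2 has no numerical value on this read-out. Compound 2 is reported only as > 30000 nM, which is a limit. Compound 3 is the only one of the three with a number, 10300 nM. The series therefore stands largely at the limit of > 30000 nM in this assay, at which 2 of the 3 values shown sit.

The next compound is compound 4 `Cc1ccc(Nc2ncc(C(F)(F)F)c(N3Cc4cccc(N(C)S(C)(=O)=O)c4C3)n2)c(C)c1`, which has not yet been measured. The change from compound 2 is 2,4-dimethylphenyl in place of 2-methoxy-5-(trifluoromethyl)phenyl on a nitrogen on an aromatic ring. In words, 2,4-dimethylphenyl stands in place of 2-methoxy-5-(trifluoromethyl)phenyl on a nitrogen on an aromatic ring.

Among the compounds with values here, only one measured step bears on this change, a step that the two limits leave unreadable from compound 1 to compound 2. Both of its ends are limits, so it gives no size and no direction. The closest guide is compound 1, which also carries a dimethylphenyl group. No clear gain is expected for compound 4 in this assay because compound 1 gives > 30000 nM, which is also a limit, and compound 4 is expected to stay close to that limit. The expected step is a number no higher from compound 2 to compound 4 (the limit leaves the size open). For compound 4 the estimate is 30000 nM, with an expected range from 12000 nM to 60000 nM.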

Compound 4, concentration for 50% growth inhibition: 19100 nM
Compound 4: the middle estimate sits 1.6-fold (0.20 log units) above what was measured; the range from low to high includes it.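

In this assay compound 4 gives 19100 nM, which makes it the only compound shown with a dimethylphenyl group on this nitrogen to carry a number rather than a limit. Setting 2,4-dimethylphenyl in place of 3,4-dimethylphenyl gives an at least 1.5-fold lower number from compound 1 to compound 4 (0.19 log units; that floor lies within the scatter), and setting it in place of 2-methoxy-5-(trifluoromethyl)phenyl gives an at least 1.5-fold lower number from compound 2 to compound 4 (0.19 log units; that floor lies within the scatter). Both steps therefore set only a floor on the change, and neither floor is beyond the usual scatter, as both start from a value that is not a number: the limit of > 30000 nM in this assay, at which 2 of the 4 values shown sit.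

The size of either step remains open, so the compounds shown do not settle whether the arrangement of the two methyl groups, or the exchange of the larger group containing oxygen and fluorine for the all-carbon 2,4-dimethylphenyl, makes a real difference at this position. They also leave open how a phenyl group carrying an amine or a carboxylic acid on this nitrogen would read in this assay.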